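Taking the chloro group off compound 3

The source may hold more compounds than are shown below. What is called first, only, known or untested is meant among the compounds shown, and "the series" means these compounds.

For the measured compounds named here, the values measured so far in a functional assay on MOLT-4 cells (Homo sapiens) for cytotoxicity, read by CCK-8 assay, with a stated time of 24 h (on this read-out lower numbers stand for stronger inhibition and higher numbers for weaker inhibition), are these.
Compound 1 `C=CC(=O)N1C(=O)CCSc2ccccc21` gives 565000 nM
Compound 2 `C=CC(=O)N1C(=O)CC(c2cccs2)Sc2ccccc21` gives 557000 nM
Compound 3 `C=CC(=O)N1C(=O)CC(c2cccc(Cl)c2)Sc2ccccc21` gives 77500 nM

Compound 3 has the lowest of the three numbers, and its distance to each of the other two lies beyond the scatter. Putting thiophen-2-yl on a saturated ring carbon of the core makes no real difference, with a 1.0-fold lower number from compound 1 to compound 2 (0.01 log units; within the scatter). Putting 3-chlorophenyl there does make one, with a 7.3-fold lower number from compound 1 to compound 3 (0.86 log units; beyond the scatter). Replacing thiophen-2-yl with 3-chlorophenyl gives a matching result, with a 7.2-fold lower number from compound 2 to compound 3 (0.86 log units; beyond the scatter).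

Compound 4 `C=CC(=O)N1C(=O)CC(c2ccccc2)Sc2ccccc21` has hydrogen in place of chloro on an aromatic carbon, so 3-chlorophenyl becomes phenyl: hydrogen in place of chloro on an aromatic carbon. Going by the values given here, no measured step tests the chloro group alone, so the share of the modest gain seen in a 7.3-fold lower number from compound 1 to compound 3 (0.86 log units; beyond the scatter) that would survive its removal is unknown. That step also gives a sensible yardstick, as losing the whole gain would bring the number back to the level of compound 1 at 565000 nM. A modest rise in this assay is therefore expected, covering part of that distance, with an estimated 2.5-fold higher number from compound 3 to compound 4 (0.39 log units; beyond the scatter). Compound 4 is estimated at 190000 nM, with an expected range from 70000 nM to 560000 nM.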

Compound 4, half-maximal inhibitory concentration: 85900 nM
Compound 4: middle estimate off by 2.2-fold (0.34 log units), on the high side; the measured number falls inside the stated range.
By their numbers in this assay, from the lowest: compounds 3 and 4 (each within the scatter of the next); then compounds 2 and 1 (each within the scatter of the next).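

Removing the chloro group gives a 1.1-fold higher number from compound 3 to compound 4 (0.04 log units; within the scatter) in this assay and so leaves no measurable change, which shows that the gain seen with compound 3 does not depend on chloro at this place on the ring. Plain phenyl on the saturated ring carbon is enough to carry that gain: adding it to the core gives a 6.6-fold lower number from compound 1 to compound 4 (0.82 log units; beyond the scatter) and using it in place of thiophen-2-yl gives a 6.5-fold lower number from compound 2 to compound 4 (0.81 log units; beyond the scatter) as a further measured step. At this position the choice of ring therefore matters in these compounds, whereas the choice between chloro and hydrogen on the phenyl ring does not. No measurement shown offers an explanation for either finding.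

The compounds shown leave open whether any other group at the same place on the phenyl ring, such as a methoxy group, a hydroxyl group or an amine, would shift the number beyond the scatter. They also leave open whether a six-membered ring containing nitrogen, such as pyridine, would behave like phenyl or like thiophen-2-yl on the saturated ring carbon.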